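The source may hold more compounds than are shown below. What is called first, only, known or untested is meant among the compounds shown, and "the series" means these compounds.

In a functional assay on MV4-11 cells (Homo sapiens) for inhibition, read by resazurin assay, with a stated time of 72 h (on this read-out higher numbers stand for weaker inhibition of growth and lower numbers for stronger inhibition of growth), compound 1 `O=C1NCCC12CCN(c1c(Cl)cncc1-c1ccoc1)CC2` carries furan-3-yl and gives 750 nM as its value. Compound 2 `Cc1cc(-c2cncc(Cl)c2N2CCC3(CCNC3=O)CC2)sc1C=O` carries 5-formyl-4-methylthiophen-2-yl and gives 2530 nM as its value. Compound 3 `CC(=O)c1sccc1-c1cncc(Cl)c1N1CCC2(CCNC2=O)CC1` carries 2-acetylthiophen-3-yl and stands at > 100000 nM which is a limit of the assay and not a number.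

Compound 4 `O=Cc1cc(-c2cncc(Cl)c2N2CCC3(CCNC3=O)CC2)cs1` has not yet been measured, and it differs from compound 3 in one place (5-formylthiophen-3-yl in place of 2-acetylthiophen-3-yl on an aromatic carbon). It has 5-formylthiophen-3-yl in place of 2-acetylthiophen-3-yl on an aromatic carbon.

All three measured steps bear on this change. Replacing furan-3-yl with the group of compound 2 produced a modest change (a 3.4-fold higher number from compound 1 to compound 2 (0.53 log units; beyond the scatter)). Moving to 2-acetylthiophen-3-yl produced large changes (an at least 130-fold higher number from compound 1 to compound 3 (2.12 log units; beyond the scatter) and an at least 39-fold higher number from compound 2 to compound 3 (1.59 log units; beyond the scatter)). Compound 4 has a formyl group on a thiophene, as compound 2 does (2530 nM), and lacks the acetyl group, so it is expected to fall close to that value. Three compounds are a thin basis, so the expectation stays broad. A large step to a lower number, meaning stronger inhibition of growth, is expected (an at least 50-fold lower number from compound 3 to compound 4 (1.69 log units; beyond the scatter)). For compound 4 the estimated value is 2000 nM with an expected range from 500 nM to 10000 nM in this assay.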

Compound 4, concentration for 50% growth inhibition: 730 nM
Estimate against measurement, compound 4: 2.7-fold (0.44 log units) above; measured number inside the range.
By their numbers in this assay, from the lowest: compounds 4 and 1 (each within the scatter of the next); then compound 2. At a limit, above all of these: compound 3.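

In this assay, compound 3 stands at a limit of the assay and not at a number: the limit of > 100000 nM in this assay, at which 1 of the 4 values shown sits. Even so, the change can be read as large, an at least 130-fold lower number from compound 3 to compound 4 (2.13 log units; beyond the scatter), so a thiophene carrying a carbonyl group on this aromatic carbon does not by itself go with the loss of growth inhibition, and 5-formylthiophen-3-yl retains it. The two other steps place this group among the active ones: a 3.5-fold lower number from compound 2 to compound 4 (0.54 log units; beyond the scatter) is a modest gain over 5-formyl-4-methylthiophen-2-yl, while a 1.0-fold lower number from compound 1 to compound 4 (0.01 log units; within the scatter) leaves 5-formylthiophen-3-yl and furan-3-yl indistinguishable in this read-out.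

Acetyl gives way to formyl in the step from 2-acetylthiophen-3-yl to 5-formylthiophen-3-yl, and the place of the carbonyl group on the thiophene and the thiophene's point of attachment change with it, so the compounds shown cannot say which of these changes accounts for the large step. Among these compounds, it also remains open whether the formyl group itself matters, as no compound here carries an amine, a carboxylic acid or a hydroxymethyl group in its place on the same thiophene.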